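The source may report more compounds than this note shows. Statements on the series, on what has been measured and on what is new or still open speak of the compounds shown alone.

Measured so far in a functional assay on U-251 cells (Homo sapiens) for inhibition, read by MTT assay, with a stated time of 2 days; a lower number here means a stronger inhibitor of growth, a higher number a weaker inhibitor of growth:
- compound 1 `Nc1ccccc1NC(=O)c1ccc(NCC(=O)Nc2cccc([N+](=O)[O-])c2)cc1`: 13500 nM
- compound 2 `COc1ccc(NC(=O)CNCCCC(=O)Nc2ccccc2N)cc1`: 34000 nM
- compound 3 `Nc1ccccc1NC(=O)CCCNCC(=O)Nc1cc(Cl)ccc1Cl`: 44000 nM

Compound 1 gives the lowest number of the three. Compound 2 gives 34000 nM and compound 3 gives 44000 nM, and both gaps to compound 1 are beyond the scatter, so compound 1 stands apart as the strongest growth inhibitor of the measured set.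

The next compound, compound 4 `COc1ccc(NC(=O)CNc2ccc(C(=O)Nc3ccccc3N)cc2)cc1`, is not yet measured in this assay. It differs from compound 1 in one place: 4-methoxyphenyl in place of 3-nitrophenyl on an amide-type nitrogen.

Within the data shown here, only one measured step touches the aryl group on that amide-type nitrogen: a 1.3-fold higher number from compound 2 to compound 3 (0.11 log units; within the scatter). That step swaps 4-methoxyphenyl for 2,5-dichlorophenyl on a different core and moves nothing beyond the scatter. Among the measured compounds shown here, no measured pair compares 3-nitrophenyl with 4-methoxyphenyl directly, so the expectation rests on the one aryl swap seen being flat. The estimated step from compound 1 to compound 4 is therefore small, with a slight lean toward a higher number, a 1.5-fold higher number from compound 1 to compound 4 (0.17 log units; within the scatter), which is expected to sit near the edge of the scatter.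

Compound 4 is thus expected to give about 20000 nM in this assay, with an estimated range from 9000 nM to 45000 nM.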

Compound 4, concentration for 50% growth inhibition: 25500 nM
Compound 4: the middle estimate sits 1.3-fold (0.11 log units) below what was measured, and the stated range covers the measured number.
By their numbers in this assay, from the lowest: compounds 1, 4, 2 and 3 (each within the scatter of the next, the first and the last beyond it).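

Working notes on the aryl group on the amide-type nitrogen: in this assay, the core of compound 1 gives the first direct comparison of 4-methoxyphenyl with 3-nitrophenyl, and the exchange amounts to a 1.9-fold higher number from compound 1 to compound 4 (0.28 log units; within the scatter). The nitro group is therefore not required for growth inhibition at this level on this core, since a ring carrying a methoxy group instead gives a number within the scatter. The earlier aryl swap, a 1.3-fold higher number from compound 2 to compound 3 (0.11 log units; within the scatter), was made on a different core, so both aryl swaps now available at this position are flat and neither goes against that pattern, though the two steps exchange different groups and no measurement available here explains why the position tolerates these changes.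

The compounds shown leave open whether the position tolerates a much wider range of groups, such as an unsubstituted phenyl, a pyridine ring, a carboxylic acid on the ring or a simple alkyl chain in place of the aryl group. They also leave open whether a longer chain between the ring of the shared core and the amide-type nitrogen would shift the number beyond the scatter.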